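The source may report more compounds than this note shows. Statements on the series, on what has been measured and on what is new or still open speak of the compounds shown alone.

In an ADME assay (liver) for metabolic stability, with Liver microsome (Rattus norvegicus) as the target, using microsomes and NADPH, with a stated time of 30 min, tested at 1 uM (on this read-out higher numbers stand for fast clearance and lower numbers for slow clearance), two compounds that share a core have been measured. Compound 1, `Nc1ccc(S(=O)(=O)N2CCN(c3ncc(C(O)(C(F)(F)F)C(F)(F)F)cc3-c3cccc(F)c3)CC2)cn1`, gives 52 mL.min-1.g-1. Compound 2, `NC(=O)c1cccc(-c2cc(C(O)(C(F)(F)F)C(F)(F)F)cnc2N2CCN(S(=O)(=O)c3ccc(N)nc3)CC2)c1`, gives 63 mL.min-1.g-1 in this assay. Among the compounds with values here, the only step between the measured pair, a 1.2-fold higher number from compound 1 to compound 2 (0.08 log units; within the scatter), is within the scatter, so compound 2 stands alongside compound 1 rather than apart from it, and neither number can be told from the other.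

Compound 3, `Nc1ccc(S(=O)(=O)N2CCN(c3ncc(C(O)(C(F)(F)F)C(F)(F)F)cc3-c3cccc4[nH]ncc34)CC2)cn1`, has not yet been measured in this assay. It differs from compound 2 in one place: 1H-indazol-4-yl in place of 3-carbamoylphenyl on an aromatic carbon. Within the data shown here, no measured step exchanges the whole group on this aromatic carbon for a different one; the single step seen, a 1.2-fold higher number from compound 1 to compound 2 (0.08 log units; within the scatter), alters only a substituent on that group and stays within the scatter. That step therefore offers little guidance, and with nothing pointing in either direction the number for compound 3 is expected to stay close to that of compound 2. The step of a 1.1-fold lower number from compound 2 to compound 3 (0.06 log units; within the scatter) is expected to fall within the scatter. Compound 3 is thus estimated at 55 mL.min-1.g-1, with a range from 25 mL.min-1.g-1 to 120 mL.min-1.g-1.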

Compound 3, intrinsic clearance in microsomes: 93 mL.min-1.g-1
For compound 3 the middle estimate is 1.7-fold (0.23 log units) below the measured one, and the stated range covers the measured number.
By their numbers in this assay, from the lowest: compounds 1, 2 and 3 (each within the scatter of the next).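

In this assay, the earlier pair differed only in a substituent on the phenyl group, whereas compound 3 exchanges the whole group on this aromatic carbon, ortho to a large group, for 1H-indazol-4-yl, which brings a five-membered aromatic ring with 2 hetero atoms. Even so, both readings of this exchange, a 1.5-fold higher number from compound 2 to compound 3 (0.17 log units; within the scatter) and a 1.8-fold higher number from compound 1 to compound 3 (0.25 log units; within the scatter), stay within the scatter, so the read-out does not separate 1H-indazol-4-yl from either 3-carbamoylphenyl or 3-fluorophenyl at this position. No measurement at hand bears on what lies behind these numbers.

The compounds shown all carry an aromatic group with a six-membered carbon ring on this carbon, so they leave open whether a group without one, such as a morpholine ring, a simple amine or a short alkyl chain, would give a step beyond the scatter. They also leave open whether a change elsewhere on the shared core, such as a carboxylic acid in place of the 2,2,2-trifluoro-1-hydroxy-1-(trifluoromethyl)ethyl group, would move the clearance number further than any exchange seen here.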